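The compounds below may be only part of what the source reports. "The series", "measured", "known", "first", "only" and "open" are said of these compounds alone.

Measured in a functional assay on HepG2 cells (Homo sapiens) for antiproliferative activity, read by MTT assay, with a stated time of 48 h; a lower number here means a stronger inhibitor, a higher number a weaker inhibitor:
- Compound 1 `CCCCOc1ccc(C(=O)/C=C/c2c(/C=C/c3ccc(OC)cc3)cc(OC)cc2OC)cc1`: 12.9 ug/mL
- Compound 2 `CCCCCCOc1ccc(C(=O)/C=C/c2c(/C=C/c3ccc(OC)cc3)cc(OC)cc2OC)cc1`: 16.2 ug/mL
- Compound 3 `CCOc1ccc(C(=O)/C=C/c2c(/C=C/c3ccc(OC)cc3)cc(OC)cc2OC)cc1`: 8 ug/mL

The low end of these numbers is where compound 3 sits. The steps that lead to it are a 1.6-fold lower number from compound 1 to compound 3 (0.21 log units; within the scatter) and a 2.0-fold lower number from compound 2 to compound 3 (0.31 log units; beyond the scatter). Only the second of these clears the usual scatter, and only modestly.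

Compound 4 `COc1ccc(/C=C/c2cc(OC)cc(OC)c2/C=C/C(=O)c2ccc(Cl)cc2)cc1` has chloro in place of ethoxy on an aromatic carbon.

The measured steps bear on this change only loosely. They alter the length of the saturated chain on the oxygen, and even the largest is small. None of them removes that oxygen or brings in chloro, so the effect of this swap has not been measured. With only small steps to go on, no step beyond the scatter is expected in this assay, in either direction. The estimated change is a 1.1-fold higher number from compound 3 to compound 4 (0.05 log units; within the scatter).

For compound 4 the expected value is 9 ug/mL, within an estimated range of 4 ug/mL to 20 ug/mL.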

Compound 4, half-maximal inhibitory concentration: 13.6 ug/mL
The estimate for compound 4 lay 1.5-fold (0.18 log units) below the measured number; the range from low to high includes it.
By their numbers in this assay, from the lowest: compounds 3, 1, 4 and 2 (each within the scatter of the next, the first and the last beyond it).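

Chloro in place of ethoxy gives a 1.7-fold higher number from compound 3 to compound 4 (0.23 log units; within the scatter) in this assay on this aromatic carbon, chloro in place of butoxy gives a 1.1-fold higher number from compound 1 to compound 4 (0.02 log units; within the scatter) and chloro in place of hexyloxy gives a 1.2-fold lower number from compound 2 to compound 4 (0.08 log units; within the scatter) on the same carbon. The earlier compounds shown here varied only the chain on the oxygen, whereas these steps remove the oxygen and the whole chain, and none of the three steps leaves the scatter, so within these compounds this position accepts a single chlorine atom as readily as any of the three alkoxy groups. Nothing available explains why these numbers lie so close together.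

From the compounds shown here alone, whether a different kind of group on this carbon, such as an amine or a carboxylic acid, would give a step beyond the scatter remains open. Also open, going by these compounds, is how a bare hydrogen, or another halogen such as fluoro or bromo, would compare with chloro here.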